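The source may hold more compounds than are shown below. What is called first, only, known or untested is meant among the compounds shown, and "the series" means these compounds.

Measured compounds:
compound 1 `C=CCn1c(=S)n([C@@H]2O[C@H](CO)[C@H]3OC(C)(C)O[C@H]32)c2nc(N)nc(O)c21` — 55 uM
compound 2 `C=CCn1c(=S)n(C2OC(COCc3ccccc3)[C@H]3OC(C)(C)O[C@@H]23)c2nc(N)nc(O)c21` — 47 uM
compound 3 `COc1ccc(Cn2c(=O)n(C3OC(CO)[C@@H](O)[C@H]3O)c3nc(N)nc(O)c32)cc1` — 135 uM

In a functional assay (B cells) with Mus musculus as the target (on this read-out lower numbers stand for an effect already at smaller amounts and higher numbers for an effect only at larger amounts of compound), compound 3 stands at the highest of the three numbers. Compound 1 gives 55 uM and compound 2 gives 47 uM; both gaps to compound 3 lie beyond the scatter. For the measured compounds named here, no two measured compounds differ in a single place, so no isolated step is available for comparison.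

Compound 4 `Nc1nc(O)c2c(n1)n(C1OC(CO)[C@@H](O)[C@H]1O)c(=O)n2CC(O)CO` differs from compound 3 as follows: 1,2-dihydroxyethyl in place of 4-methoxyphenyl on a saturated chain carbon bound to an aromatic nitrogen. From the compounds shown here alone, nothing measured isolates this change, so its size is unknown. In this assay a step of modest size is expected, with no direction beyond the scatter clearly favoured; the expected step is a 1.1-fold higher number from compound 3 to compound 4 (0.05 log units; within the scatter). Compound 4 is estimated at 150 uM, within a range from 50 uM to 450 uM.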

Compound 4, concentration for half-maximal effect: 45 uM
For compound 4 the middle estimate is 3.3-fold (0.52 log units) above the measured one, outside the stated range (below it).
By their numbers in this assay, from the lowest: compounds 4, 2 and 1 (each within the scatter of the next); then compound 3.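

In this assay, for the compounds shown here, 1,2-dihydroxyethyl in place of 4-methoxyphenyl on a saturated chain carbon bound to an aromatic nitrogen gives a 3.0-fold lower number from compound 3 to compound 4 (0.48 log units; beyond the scatter), the first isolated step. This position therefore responds to substitution, and in this pair the lower number does not depend on the six-membered aromatic ring. No measurement at hand accounts for the step.

From the compounds shown here alone, the step removes the ring and adds both hydroxy groups at once, so their separate contributions remain open. A plain propyl chain or an unsubstituted benzyl group at this place would separate them.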